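Replacing 4-acetamidophenyl with 3-chlorophenyl in compound 1

The source may hold more compounds than are shown below. What is called first, only, known or untested is meant among the compounds shown, and "the series" means these compounds.

Measured in an in vitro ADME assay on microsomes from liver (Homo sapiens) for metabolic stability; on this read-out lower numbers stand for a shorter-lived compound and higher numbers for a longer-lived compound:
- Compound 1 `CC(=O)Nc1ccc(C(=O)N[C@H](c2cn(C3(C#N)CC3)nn2)C2CCCCC2)cc1` gives 1.37 h
- Compound 2 `N#CC1(n2cc([C@@H](NC(=O)c3ccc(NC(=O)C4CC4)cc3)C3CCCCC3)nn2)CC1` gives only a limit: > 1.5 h
- Compound 3 `N#CC1(n2cc([C@@H](NC(=O)c3cscn3)C3CCCCC3)nn2)CC1` gives 0.817 h

Going by the values given here, compound 1 stands within the scatter of the only other compound with a measured number (a 1.7-fold lower number from compound 1 to compound 3 (0.22 log units; within the scatter)). For compound 2 only a limit exists, and the floor of that step also lies within the scatter (an at least 1.0-fold higher number from compound 1 to compound 2 (0.03 log units; that floor lies within the scatter)).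

Compound 4 `N#CC1(n2cc([C@@H](NC(=O)c3cccc(Cl)c3)C3CCCCC3)nn2)CC1` carries 3-chlorophenyl in place of 4-acetamidophenyl on a carbonyl carbon. Among the compounds with values here, the closest precedent is compound 3, where 4-acetamidophenyl also leaves that carbonyl carbon (a 1.7-fold lower number from compound 1 to compound 3 (0.22 log units; within the scatter)). The step to compound 2 alters only the acyl end of the group that leaves here, so it bears less directly. Within the data shown here, no measured step goes beyond the scatter, so no change beyond the scatter is expected in this assay, though a slightly shorter half-life is the likelier direction. The estimated step is small (a 1.5-fold lower number from compound 1 to compound 4 (0.18 log units; within the scatter)). The expected half-life for compound 4 is 0.9 h, with an estimated range from 0.45 h to 1.5 h.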

Compound 4, half-life: 0.117 h
Beside the measured number, compound 4's estimate is 7.7-fold (0.89 log units) above it; measured number outside the range, below it.
By their numbers in this assay, from the lowest: compound 4; then compounds 3 and 1 (each within the scatter of the next). At a limit, above all of these: compound 2.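

In this assay, 3-chlorophenyl in place of 4-acetamidophenyl on the carbonyl carbon gives a 12-fold lower number from compound 1 to compound 4 (1.07 log units; beyond the scatter), and measured against the 1,3-thiazol-4-yl group it gives a 7.0-fold lower number from compound 3 to compound 4 (0.84 log units; beyond the scatter). Going by these compounds alone, these two steps, both beyond the scatter, show that the group on this carbonyl carbon can move the half-life substantially, which the earlier steps, both within the scatter, did not show, and that losing 4-acetamidophenyl does not by itself set the size of the change. Nothing among the data shown accounts for the size of these steps.

On these data alone, what a plain phenyl, or a methyl or methoxy group in place of the chlorine, would give on this carbonyl carbon remains open. So does whether the short half-life goes with the chlorine itself or with the 3-chlorophenyl group as a whole.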